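Cytotoxicity notes on compounds 1 to 4

The compounds below may be only part of what the source reports. "The series", "measured", "known", "first", "only" and "open" are said of these compounds alone.

Measured so far:
Compound 1 `CC(=O)Nc1cccc(-c2ccc(C(=O)N(Cc3cccc(OCCCCCC(=O)O)c3)C(C)C)cc2)c1`: in an ADME assay on HEK293 cells (Homo sapiens) for cytotoxicity, read by CellTiter-Glo and resazurin assay, with a stated time of 72 h (a higher number here means that more compound is needed for the effect, a lower number that less compound is needed), compound 1 gives > 26000 nM, which is a limit of the assay, not a number.
Compound 2 `CC(C)N(Cc1cccc(OCCCCCC(=O)O)c1)C(=O)c1ccc(-c2ccco2)cc1`: compound 2 gives > 26000 nM, again a limit.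
Compound 3 `CC(C)N(Cc1cccc(OCCCCCC(=O)O)c1)C(=O)c1ccc(-c2ccsc2)cc1`: compound 3 gives > 26000 nM, also a limit.

Compound 3 therefore stands only at a limit in this assay, as do the other two values, all three sitting at the limit of > 26000 nM in this assay, at which 3 of the 3 values shown sit. The next compound is compound 4 `CC(C)N(Cc1cccc(OCCCCCC(=O)O)c1)C(=O)c1ccc(-c2cccc(OC(F)(F)F)c2)cc1`; the change is 3-(trifluoromethoxy)phenyl in place of thiophen-3-yl on an aromatic carbon. The steps a step that the two limits leave unreadable from compound 1 to compound 3 and a step that the two limits leave unreadable from compound 2 to compound 3 bear on this change, but their sizes cannot be read, as both ends are limits. No step beyond the scatter can be expected from these data, and compound 4 is expected to sit at the limit too. The step that the limit leaves unreadable from compound 3 to compound 4 is thus expected to be flat. Compound 4 is estimated at 30000 nM, within 12000 nM to 80000 nM.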

Compound 4, half-maximal effective concentration: > 26000 nM
Compound 4: a limit, no number; the forecaster's own chance of this, stated with the estimate: 80%; the middle value lies beyond the limit too.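

All four compounds stand at a limit, and no step to compound 4 from compound 1, compound 2 or compound 3 can be read: the limit of > 26000 nM in this assay, at which 4 of the 4 values shown sit.

In this assay the compounds shown leave open whether any group on the shared core gives a measurable value.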